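Two Sulfonamides at the Limit, and a Fluoro Analogue

The compounds below may be only part of what the source reports. "The series", "measured", "known", "first", "only" and "open" are said of these compounds alone.

Measured so far:
compound 1, `Cc1ccc(S(=O)(=O)Nc2ccc3oc(-c4ccccc4)nc3c2)cc1` — > 63000 nM
compound 2, `O=S(=O)(Nc1ccc(-c2nc3ccccc3o2)cc1)c1ccccc1Cl` — > 63000 nM

In an assay on isolated protein for inhibition of malate dehydrogenase, mitochondrial (Sus scrofa), with stated times of 45 min and 30 min (a lower number here means a stronger inhibitor, a higher number a weaker inhibitor), compound 1 reaches only a limit of the assay, > 63000 nM. Compound 2 likewise gives only a limit in this assay, > 63000 nM. Where compound 2 stands can thus be stated only as a bound, not as a number, and it cannot be ranked against compound 1. Every value obtained so far sits at the limit of > 63000 nM in this assay, at which 2 of the 2 values shown sit.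

Compound 3, `O=S(=O)(Nc1ccc(-c2nc3ccccc3o2)cc1)c1ccccc1F`, differs from compound 2 in one place: fluoro in place of chloro on an aromatic carbon. Going by the values given here, no step between two measured compounds is available to size such a change, so nothing measured tells how far a swap of this kind moves the read-out. The expectation is therefore that compound 3 stays where compound 2 stands, with no shift beyond the scatter, which is what a step that the limit leaves unreadable from compound 2 to compound 3 expresses. Compound 3 is estimated at 100000 nM, within 40000 nM to 300000 nM, and is expected most likely to be reported again as a limit rather than a number.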

Compound 3, half-maximal inhibitory concentration: > 63000 nM
Compound 3: no number, only a limit; the forecaster's own chance of this, stated with the estimate: 85%; the middle value does not contradict the limit.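

Compound 3 gives > 63000 nM in this assay and this too is only a limit. Going by these compounds alone, no step can therefore be read between compound 2 and compound 3, so the swap of chloro for fluoro has no size that can be stated. The compounds shown leave open whether this series gives a true number in this assay at all: the limit of > 63000 nM in this assay, at which 3 of the 3 values shown sit.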